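Compound 3 to compound 4: swapping the nitrogen substituent

This account rests on a few compounds, and the source may have more. Where it says the series, first, only, none or still open, it means among the compounds named here.

Within the data shown here, in a functional assay on MGC-803 cells (Homo sapiens) for inhibition, read by sulforhodamine B assay (a higher number here means a weaker inhibitor, a lower number a stronger inhibitor), compound 3 `CCOc1ccccc1NC1=CC(=O)c2c(nc3n2[C@H]2OC[C@@H](O)[C@H]2OC3)C1=O` gives 2830 nM, the only true number among the measured compounds. Compound 1 `O=C1C(N2CCCCC2)=CC(=O)c2c1nc1n2[C@H]2OC[C@@H](O)[C@H]2OC1` reads > 4000 nM, which is a limit of the assay. Compound 2 `O=C1C(N2CCC2)=CC(=O)c2c1nc1n2[C@H]2OC[C@@H](O)[C@H]2OC1` reads > 16000 nM, also a limit. Compound 4 `O=C1C(Nc2cccc(Cl)c2)=CC(=O)c2c1nc1n2[C@H]2OC[C@@H](O)[C@H]2OC1` differs from compound 3 by 3-chlorophenyl in place of 2-ethoxyphenyl on an amine nitrogen. Among the measured compounds shown here, the sole measured step, a step that the two limits leave unreadable from compound 1 to compound 2, has no readable size and involves different groups, so it offers no guide here. For the measured compounds named here, with no sized step bearing on this change, no shift beyond the scatter is expected in this assay, and the expectation rests on compound 3 at 2830 nM. The expected step is a 1.1-fold lower number from compound 3 to compound 4 (0.05 log units; within the scatter). For compound 4 the estimate is 2500 nM, with an expected range from 700 nM to 9000 nM.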

Compound 4, half-maximal inhibitory concentration: 1530 nM
Compound 4: the middle estimate sits 1.6-fold (0.21 log units) above what was measured; low and high end bracket the measured number.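

On the double-bonded ring carbon, (3-chlorophenyl)amino in place of azetidin-1-yl gives an at least 10-fold lower number from compound 2 to compound 4 (1.01 log units; beyond the scatter), and in place of piperidin-1-yl it gives an at least 2.6-fold lower number from compound 1 to compound 4 (0.41 log units; beyond the scatter). Both steps are sized against assay limits, so the true gaps may be wider. On the amine nitrogen, 3-chlorophenyl in place of 2-ethoxyphenyl gives a 1.8-fold lower number from compound 3 to compound 4 (0.27 log units; within the scatter), which leaves the two phenyl groups unseparated.

Still open, from the compounds shown here alone, is whether a benzylamino or morpholin-4-yl group on this carbon would match compound 4. Also open, going by these compounds, is whether an unsubstituted phenyl on the amine nitrogen would read the same.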